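Chloro removal on the benzyl group across two cores

This account rests on a few compounds, and the source may have more. Where it says the series, first, only, none or still open, it means among the compounds named here.

Compound 3 `CN(CCCc1cn(-c2ccc(F)cc2)c2ccccc12)Cc1cccc(Cl)c1` and compound 2 `CN(CCCc1cn(-c2ccc(F)cc2)c2ccccc12)Cc1ccccc1` share one core and differ by hydrogen in place of chloro on an aromatic carbon. In an assay on liver for displacement of a labelled ligand from Sigma non-opioid intracellular receptor 1 (Rattus norvegicus) (on this read-out higher numbers stand for weaker inhibition and lower numbers for stronger inhibition), compound 3 gives 98.9 nM and compound 2 gives 20.8 nM, which amounts to a 4.8-fold lower number from compound 3 to compound 2 (0.68 log units; beyond the scatter). Compound 1 `CN(CCCCc1cn(-c2ccc(F)cc2)c2ccccc12)Cc1cccc(Cl)c1` carries the same 3-chlorobenzyl group on a second core; the difference between the two cores is not broken down here. In this assay compound 1 gives 201 nM. Compound 4 `CN(CCCCc1cn(-c2ccc(F)cc2)c2ccccc12)Cc1ccccc1` has not yet been measured; it differs from compound 1 by hydrogen in place of chloro on an aromatic carbon, the same change as that between compound 3 and compound 2. Resting on a 4.8-fold lower number from compound 3 to compound 2 (0.68 log units; beyond the scatter), a step of about a 4.5-fold lower number from compound 1 to compound 4 (0.65 log units; beyond the scatter) is expected in this assay. Compound 4 is therefore estimated at 45 nM, with a likely range from 20 nM to 100 nM.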

Compound 4, inhibition constant: 43 nM
The estimate for compound 4 lay 1.0-fold (0.02 log units) above the measured number; the measured number falls inside the stated range.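

Hydrogen in place of chloro on the 3-chlorobenzyl group gives a 4.7-fold lower number from compound 1 to compound 4 (0.67 log units; beyond the scatter) in this assay. The step carries over between the two cores with no difference in size beyond the scatter: the same change on two cores in this assay, a 4.8-fold lower number (0.68 log units; beyond the scatter) from compound 3 to compound 2 and a 4.7-fold lower number (0.67 log units; beyond the scatter) from compound 1 to compound 4, 1.0-fold (0.01 log units) apart, within the scatter of two such steps. This rests on one pair per core in a single assay, so it shows agreement for these two cores only and does not show why the steps match or whether the same step would hold on any other core.

Going by these compounds, whether a fluoro or a methoxy group on the benzyl group would give a step like that of the chloro remains open. So does whether the step holds on a core with a longer chain.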